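The source may hold more compounds than are shown below. What is called first, only, known or untested is meant among the compounds shown, and "the series" means these compounds.

Measured compounds:
compound 1 `COc1ccc(/C=C/C(=O)c2cccc(-n3cc(-c4ccc(F)cc4)nn3)c2)cc1O` — 2500 nM
compound 2 `CCCCCc1ccc(-c2cn(-c3cccc(C(=O)/C=C/c4ccc(OC)c(O)c4)c3)nn2)cc1` — > 30000 nM

Compound 1 `COc1ccc(/C=C/C(=O)c2cccc(-n3cc(-c4ccc(F)cc4)nn3)c2)cc1O` gives 2500 nM in a functional assay on RAW264.7 cells (Mus musculus) for inhibition, with a stated time of 4 days; a higher number here means a weaker inhibitor, a lower number a stronger inhibitor. For compound 2 `CCCCCc1ccc(-c2cn(-c3cccc(C(=O)/C=C/c4ccc(OC)c(O)c4)c3)nn2)cc1` the value > 30000 nM in this assay is a limit of the assay, not a number. Going by the values given here, the one measured step, an at least 12-fold higher number from compound 1 to compound 2 (1.07 log units; beyond the scatter), therefore rests on the limit of > 30000 nM in this assay, at which 1 of the 2 values shown sits, and gives the direction but not the full size of the loss. Compound 2 thus stands at the weak end of the two values shown.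

Compound 3 `COc1ccc(/C=C/C(=O)c2cccc(-n3cc(-c4ccccc4C(F)(F)F)nn3)c2)cc1O` differs from compound 2 by 2-(trifluoromethyl)phenyl in place of 4-pentylphenyl on an aromatic carbon. The entering group is of nearly the same heavy-atom count as the leaving one but carries three fluorines instead of a pentyl chain. The step from compound 1 to compound 2 bears on this change in that both compounds differ from compound 1 in the group on the same aromatic carbon; compound 3 has no pentyl, so the large loss seen there need not carry over. A lower number than the limit of compound 2 is expected, with a substantial step an at least 5.0-fold lower number from compound 2 to compound 3 (0.69 log units; beyond the scatter). Compound 3 is estimated at 6000 nM, within 2000 nM to 30000 nM.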

Compound 3, half-maximal inhibitory concentration: 9120 nM
Compound 3: middle estimate off by 1.5-fold (0.18 log units), on the low side, and the stated range covers the measured number.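

In this assay, the aromatic carbon of the five-membered aromatic ring with 3 nitrogen now carries a second group that gives a measurable number, and exchanging 4-pentylphenyl for 2-(trifluoromethyl)phenyl gives an at least 3.2-fold lower number from compound 2 to compound 3 (0.51 log units; beyond the scatter). Compound 2 stands at a limit and not at a number, so this step gives only a direction and a smallest size: the limit of > 30000 nM in this assay, at which 1 of the 3 values shown sits. Measured against 4-fluorophenyl, 2-(trifluoromethyl)phenyl is still a loss, with a 3.6-fold higher number from compound 1 to compound 3 (0.56 log units; beyond the scatter), so the large loss with 4-pentylphenyl does not mark the only other level at this carbon, and among the three groups shown 4-fluorophenyl gives the lowest number.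

The two exchanges leave open whether the numbers follow the identity of the substituent on the phenyl or where it stands, since 2-(trifluoromethyl)phenyl differs from 4-fluorophenyl in both respects and the pentyl chain is a third kind of group again. Also open, as far as these compounds go, is how a phenyl carrying an amine, a carboxylic acid or an ethyl chain would read at this carbon in this assay, and whether any group there gives a lower number than 4-fluorophenyl.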